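Methyl on the anilino ring: compound 2 to compound 3

The source may report more compounds than this note shows. Statements on the series, on what has been measured and on what is new or still open speak of the compounds shown alone.

Compound 2 `Cc1nc(Nc2ccccc2)sc1C(=O)/C=C/c1ccccc1`: > 25000 nM
Compound 1 `Cc1cccc(Nc2nc(C)c(C(=O)/C=C/c3ccccc3Cl)s2)c1`: > 25000 nM

In a functional assay on NCI-H460 cells (Homo sapiens) for cytotoxicity, read by MTT assay (on this read-out lower numbers stand for stronger inhibition and higher numbers for weaker inhibition), compound 2 gives > 25000 nM, which is a limit of the assay rather than a number. Compound 1 likewise gives > 25000 nM, also a limit. Both measured values therefore sit at the limit of > 25000 nM in this assay, at which 2 of the 2 values shown sit, so compound 2 stands at the weak end of what the assay can report. Compound 3 `Cc1cccc(Nc2nc(C)c(C(=O)/C=C/c3ccccc3)s2)c1` differs from compound 2 by methyl in place of hydrogen on an aromatic carbon. Among the measured compounds shown here, no measured step shows what such a change does here; the step that the limit leaves unreadable from compound 2 to compound 3 is expected to be none beyond the scatter. Compound 3 is expected to give 30000 nM, within 12000 nM to 100000 nM, most likely again reported as a limit.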

Compound 3, half-maximal inhibitory concentration: 21800 nM
For compound 3 the middle estimate is 1.4-fold (0.14 log units) above the measured one, within the range that was stated.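

In this assay, among the compounds shown here, compound 3 gives 21800 nM, the only one of the three values shown that is a number and not a limit. Methyl on the anilino ring brings an at least 1.1-fold lower number from compound 2 to compound 3 (0.05 log units; that floor lies within the scatter), and hydrogen in place of chloro brings an at least 1.1-fold lower number from compound 1 to compound 3 (0.05 log units; that floor lies within the scatter). Both steps are floors that stay within the scatter, so neither change is shown to matter, and their true size cannot be read: the limit of > 25000 nM in this assay, at which 2 of the 3 values shown sit.

From the compounds shown here alone, how far either step really runs remains open. So does what a methoxy group or an amine on the anilino ring would do.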